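The source may report more compounds than this note shows. Statements on the series, on what has been measured and on what is new or still open speak of the compounds shown alone.

Working notes on the series. Compound 1 `COc1cccc(-n2cc(COc3c(/C=C\C(=O)O)ccc(OC)c3CC=C(C)C)nn2)c1` and compound 3 `COc1ccc(/C=C\C(=O)O)c(OCc2cn(-c3nc4ccccc4s3)nn2)c1CC=C(C)C` share the core and carry an aromatic group on the ring nitrogen of the five-membered aromatic ring with 3 nitrogen. In a functional assay on NCI-H322 cells (Homo sapiens) for cytotoxicity, read by MTT assay, with a stated time of 24 h (on this read-out higher numbers stand for weaker inhibition and lower numbers for stronger inhibition), compound 1 gives 25200 nM, and in this assay compound 3 gives 23000 nM. For the measured compounds named here, the only single-point step measured so far, a 1.1-fold lower number from compound 1 to compound 3 (0.04 log units; within the scatter), shows that swapping the aromatic group on that nitrogen left the read-out essentially unchanged.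

Compound 2 `COc1ccc(-n2cc(COc3c(/C=C\C(=O)O)ccc(OC)c3CC=C(C)C)nn2)cc1` carries a 4-methoxyphenyl at the same position; in this assay compound 2 stands as "not determined" (no result reported), so no number anchors it, and its standing can only be inferred from compound 1 and compound 3, which sit close together.

Compound 4 `COc1ccc(/C=C\C(=O)O)c(OCc2cn(-c3ccccc3C#N)nn2)c1CC=C(C)C` is compound 2 with 2-cyanophenyl in place of 4-methoxyphenyl on an aromatic nitrogen. Going by the values given here, the one step that bears on this kind of change, a 1.1-fold lower number from compound 1 to compound 3 (0.04 log units; within the scatter), was within the scatter, so the expectation in this assay for a further variation of the group on the aromatic nitrogen is no step beyond the scatter, in either direction, anchored on the numbers of compound 1 and compound 3.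

On that basis compound 4 is expected to give about 24000 nM in this assay, with an estimated range from 10000 nM to 58000 nM.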

Compound 4, half-maximal inhibitory concentration: 14400 nM
Compound 4: the middle estimate sits 1.7-fold (0.22 log units) above what was measured; measured number inside the range.
By their numbers in this assay, from the lowest: compounds 4, 3 and 1 (each within the scatter of the next).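

In this assay, the two new steps, a 1.6-fold lower number from compound 3 to compound 4 (0.20 log units; within the scatter) and a 1.8-fold lower number from compound 1 to compound 4 (0.24 log units; within the scatter), both stay within the scatter, so 2-cyanophenyl on the aromatic nitrogen reads the same as 3-methoxyphenyl and 1,3-benzothiazol-2-yl. The earlier compounds shown here offered a single step at this position, whereas compounds 1, 3 and 4 now give three pairs, and none of them separates beyond the scatter. Across these three compounds, then, a nitrile-bearing phenyl, a methoxy-bearing phenyl and a benzothiazolyl group on this nitrogen cannot be told apart by this read-out, and the data on hand offer no explanation for that flatness.

Compound 2 has no reported result, so steps to or from it cannot be read, and the 4-methoxyphenyl group stays unplaced in this comparison. The compounds shown also leave open whether a group without an aromatic ring on this nitrogen, such as a simple alkyl chain, or a phenyl carrying an amine or a carboxylic acid, would produce a step beyond the scatter in this assay.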